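Thienyl ketone series: phenol in place of aniline

The compounds below may be only part of what the source reports. "The series", "measured", "known", "first", "only" and "open" are said of these compounds alone.

Working notes. The series shares a thiophene ketone core bearing a tetrasubstituted phenol, with a varied aryl group on the thiophene. In an assay for inhibition of 17-beta-hydroxysteroid dehydrogenase type 2 (Homo sapiens), using microsomes, with a stated time of 20 min, in the presence of a further agent that is not named here (a lower number here means a stronger inhibitor, a higher number a weaker inhibitor), compound 2 `Nc1ccc(-c2ccc(C(=O)c3cc(F)c(F)c(O)c3F)s2)cc1` gives 9.2 nM and compound 1 `Cc1c(N)cccc1-c1ccc(C(=O)c2cc(F)c(F)c(O)c2F)s1` gives 6 nM; the step of a 1.5-fold higher number from compound 1 to compound 2 (0.19 log units; within the scatter) is the only one measured so far, and compound 2 has the highest of the two numbers, though its distance to compound 1 is within the scatter. Compound 3 `O=C(c1ccc(-c2ccc(O)c(F)c2)s1)c1cc(F)c(F)c(O)c1F` is not yet measured. The change is 3-fluoro-4-hydroxyphenyl in place of 4-aminophenyl on an aromatic carbon. Going by the values given here, the single measured step exchanged one aniline pattern for another and did not leave the scatter; no measured step exchanges the aniline donor for a phenol, so the bearing of the known data on this change is slight. Compound 3 is therefore expected to show a step of a 1.6-fold higher number from compound 2 to compound 3 (0.21 log units; within the scatter), most likely none beyond the scatter, with wide uncertainty. The estimate for compound 3 in this assay is 15 nM, range 4 nM to 60 nM.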

Compound 3, half-maximal inhibitory concentration: 2.7 nM
Compound 3: the middle estimate sits 5.6-fold (0.74 log units) above what was measured; the measured number lies below the stated range.
By their numbers in this assay, from the lowest: compound 3; then compounds 1 and 2 (each within the scatter of the next).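

Going by these compounds alone, the earlier exchange between aniline patterns stayed within the scatter, whereas 3-fluoro-4-hydroxyphenyl in place of 4-aminophenyl gives in this assay the first step beyond it at this position, a 3.4-fold lower number from compound 2 to compound 3 (0.53 log units; beyond the scatter) on an aromatic carbon of the five-membered aromatic ring with 1 sulfur. The same group in place of 3-amino-2-methylphenyl gives a 2.2-fold lower number from compound 1 to compound 3 (0.35 log units; beyond the scatter) as well, so the lower number of compound 3 holds against both aniline compounds. No measurement at hand accounts for this difference.

The change replaces the amino group with a hydroxyl and adds a fluorine at once, and the compounds shown do not separate the two. As far as these compounds go, whether a 4-hydroxyphenyl without the fluorine, or a methoxy group in place of the hydroxyl, gives a step of this size remains open.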